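The source may hold more compounds than are shown below. What is called first, only, known or untested is meant among the compounds shown, and "the series" means these compounds.

Compound 1 `O=C(/C=C\c1ccc(O)cc1)N1N=C(c2ccncc2)OC1c1c[nH]c2ccccc12` – in an ADME assay on PANC-1 cells (Homo sapiens) for cytotoxicity, read by MTT assay, with a stated time of 48 h (a lower number here means a stronger inhibitor of growth, a higher number a weaker inhibitor of growth), compound 1 gives only a limit, > 30 ug/mL.
Compound 2 `O=C(/C=C\c1cccc([N+](=O)[O-])c1)N1N=C(c2ccncc2)OC1c1c[nH]c2ccccc12` – in this assay compound 2 gives only a limit, > 30 ug/mL.
Compound 3 `O=C(/C=C\c1ccc([N+](=O)[O-])cc1)N1N=C(c2ccncc2)OC1c1c[nH]c2ccccc12` – in this assay compound 3 gives only a limit, > 30 ug/mL.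

Compound 3 therefore stands at a limit rather than on a number, and the two further values shown are limits as well (the limit of > 30 ug/mL in this assay, at which 3 of the 3 values shown sit). The three steps among the measured compounds are all left unreadable by these limits: a step that the two limits leave unreadable from compound 1 to compound 2, a step that the two limits leave unreadable from compound 1 to compound 3 and a step that the two limits leave unreadable from compound 2 to compound 3.

Compound 4 `O=C(/C=C\c1cccc(F)c1)N1N=C(c2ccncc2)OC1c1c[nH]c2ccccc12` has not yet been measured. It differs from compound 3 by 3-fluorophenyl in place of 4-nitrophenyl on a double-bonded chain carbon bound to a double-bonded chain carbon. For the measured compounds named here, the one measured step that touches the same place on the chain is a step that the two limits leave unreadable from compound 2 to compound 3, and its size cannot be read; the two other steps are equally unreadable. Going by the values given here, no measured step thus gives a readable size that bears on the change to compound 4.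

Compound 4 is accordingly expected to remain at the limit, with an estimate of 45 ug/mL and a range from 20 ug/mL to 120 ug/mL. The expected step that the limit leaves unreadable from compound 3 to compound 4 is not expected to show any reading beyond the scatter.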

Compound 4, concentration for 50% growth inhibition: > 30 ug/mL
Compound 4 gave a limit, no number; the forecaster's own chance of this, stated with the estimate: 80%; the middle value is on the limit's open side.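

In this assay compound 4 gives only a limit, > 30 ug/mL, so its steps to compound 1, compound 2 and compound 3 cannot be read. The compounds shown leave open how strongly any of them inhibits growth and whether the changes on the chain make any difference: the limit of > 30 ug/mL in this assay, at which 4 of the 4 values shown sit.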